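The source may hold more compounds than are shown below. What is called first, only, known or untested is meant among the compounds shown, and "the series" means these compounds.

Compound 1 `CSc1ccc(C)cc1NCC1=NCCN1` is the reference of the set: in an assay for binding affinity to Alpha-1A adrenergic receptor (Homo sapiens), read by radioligand binding (a higher number here means a weaker inhibitor, a lower number a stronger inhibitor), compound 1 gives 20.9 nM. Compound 2 `Cc1ccc(S(C)(=O)=O)c(NCC2=NCCN2)c1` differs from it by methylsulfonyl in place of methylsulfanyl on an aromatic carbon, and in this assay compound 2 gives 776 nM, which is a 37-fold higher number from compound 1 to compound 2 (1.57 log units; beyond the scatter). Compound 3 `CSc1c(F)cccc1NCC1=NCCN1` carries a different core; how the core of compound 3 differs from the core of compound 1 is not broken down here. In this assay compound 3 gives 148 nM, a number between those of compound 1 and compound 2.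

Compound 4 `CS(=O)(=O)c1c(F)cccc1NCC1=NCCN1` remains to be measured. It differs from compound 3 by methylsulfonyl in place of methylsulfanyl on an aromatic carbon. This is the same kind of change as that from compound 1 to compound 2, though not the same: there the place was ortho to a group of 7 heavy atoms and para to a methyl group, here it is ortho to a fluoro group and ortho to a group of 7 heavy atoms. The surroundings of the place differ, so the repeat is not exact. The expected step is a 27-fold higher number from compound 3 to compound 4 (1.43 log units; beyond the scatter), an estimate that rests on the measured step of a 37-fold higher number from compound 1 to compound 2 (1.57 log units; beyond the scatter) and allows for the changed surroundings. In this assay compound 4 is expected to give 4000 nM, estimated to lie between 1500 nM and 12000 nM.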

Compound 4, inhibition constant: 550 nM
Beside the measured number, compound 4's estimate is 7.3-fold (0.86 log units) above it, and the stated range ends above it.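

In this assay the replacement of methylsulfanyl by methylsulfonyl raises the number on the second core as well, with a 3.7-fold higher number from compound 3 to compound 4 (0.57 log units; beyond the scatter), so the direction of the change holds on both cores shown. The size of the step does not carry over, and the gap between the two steps lies beyond the scatter: the same change on two cores in this assay, a 37-fold higher number (1.57 log units; beyond the scatter) from compound 1 to compound 2 and a 3.7-fold higher number (0.57 log units; beyond the scatter) from compound 3 to compound 4, 10-fold (1.00 log units) apart, beyond the scatter of two such steps. Two pairs show that the sign of this change repeats on these two cores, but they do not show what sets the size of the step, and they give no firm size for the same change on a further core.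

Still open, on these data alone, is which part of the difference between the core of compound 1 and the core of compound 3 goes with the smaller step, including any part played by the fluoro group. Also open is how a methylsulfinyl group, an amine or a carboxylic acid would read at this place on either core, where the compounds shown carry only methylsulfanyl and methylsulfonyl.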